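This account rests on a few compounds, and the source may have more. Where it says the series, first, only, none or still open, it means among the compounds named here.

Measured in a functional assay on OVCAR-5 cells (Homo sapiens) for inhibition, read by sulforhodamine B assay, with a stated time of 48 h; on this read-out lower numbers stand for stronger inhibition of growth and higher numbers for weaker inhibition of growth:
compound 1 `O=C(CCCCN1C/C=C/CCOc2cccc(c2)-c2ccnc(n2)Nc2cccc(c2)C1)NO`: 1220 nM
compound 2 `O=C(CCCCCCN1C/C=C/COCc2cccc(c2)-c2ccnc(n2)Nc2cccc(c2)C1)NO`: 1420 nM

Among the measured compounds shown here, compound 1 and compound 2 lie within the scatter of each other, so compound 1 does not stand apart from the only other measured compound. Compound 3 `O=C(CCCCC(=O)N1C/C=C/CCOc2cccc(c2)-c2ccnc(n2)Nc2cccc(c2)C1)NO` keeps the core of compound 1 and alters one place, on an amine nitrogen in a ring: (4-(hydroxycarbamoyl)butyl)carbonyl in place of 4-(hydroxycarbamoyl)butyl on an amine nitrogen in a ring. There, (4-(hydroxycarbamoyl)butyl)carbonyl stands in place of 4-(hydroxycarbamoyl)butyl. For the measured compounds named here, no measured pair differs at this one place alone, so the data offer no direct guide to this change. In this assay, a small step toward weaker inhibition of growth is expected, and it may not exceed the scatter. The estimate amounts to an expected 1.5-fold higher number from compound 1 to compound 3 (0.17 log units; within the scatter). The expected value for compound 3 is 1800 nM, with an estimated range of 600 nM to 5500 nM.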

Compound 3, concentration for 50% growth inhibition: 1520 nM
The estimate for compound 3 lay 1.2-fold (0.07 log units) above the measured number; the range from low to high includes it.
By their numbers in this assay, from the lowest: compounds 1, 2 and 3 (each within the scatter of the next).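

In this assay, (4-(hydroxycarbamoyl)butyl)carbonyl in place of 4-(hydroxycarbamoyl)butyl on the amine nitrogen in the ring gives a 1.2-fold higher number from compound 1 to compound 3 (0.10 log units; within the scatter). Among the compounds shown here, this is the first direct reading at this position, and it does not separate the carbonyl-linked chain from the plain chain, so on this read-out the series tolerates the change on the shared core. No supporting measurement bears on why the two compounds read alike.

Compound 2 differs from compound 1 and compound 3 in more than one place, so it does not show how chain length acts at this nitrogen on its own. Still open, going by these compounds, is whether a longer chain on the carbonyl, or a carboxylic acid in place of the hydroxycarbamoyl end, would move the number beyond the scatter.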